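Moving the fluorine on the benzyl arm

The source may report more compounds than this note shows. Statements on the series, on what has been measured and on what is new or still open speak of the compounds shown alone.

Measured so far in an assay on isolated protein for inhibition of histone deacetylase 11 (Homo sapiens), read by mobility shift assay; a higher number here means a weaker inhibitor, a lower number a stronger inhibitor:
compound 1 `O=C(NO)c1ccc(CN(Cc2ccncc2)S(=O)(=O)c2cc(F)c(F)c(F)c2F)cc1` gives 472 nM
compound 2 `O=C(NO)c1ccc(CN(Cc2ccccc2)S(=O)(=O)c2cc(F)c(F)c(F)c2F)cc1` gives 115 nM
compound 3 `O=C(NO)c1ccc(CN(Cc2ccc(F)cc2)S(=O)(=O)c2cc(F)c(F)c(F)c2F)cc1` gives > 1000 nM, a limit of the assay rather than a number

Compound 3 stands at the weak end of the three. Its value is only a limit, (the limit of > 1000 nM in this assay, at which 1 of the 3 values shown sits), so its distance from the others is known as a floor, not as a number. Compound 2 is the stronger of the two numbered compounds, as a 4.1-fold lower number from compound 1 to compound 2 (0.61 log units; beyond the scatter) shows.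

The next step is compound 4 `O=C(NO)c1ccc(CN(Cc2cccc(F)c2)S(=O)(=O)c2cc(F)c(F)c(F)c2F)cc1`, which differs from compound 3 only in the change (3-fluorophenyl in place of 4-fluorophenyl on a saturated chain carbon bound to a sulfonamide nitrogen); the two have the same atoms, joined differently, the same difference cut one bond further out reading 4-fluorobenzyl to 3-fluorobenzyl.

Of the measured steps, an at least 8.6-fold higher number from compound 2 to compound 3 (0.93 log units; beyond the scatter) is the one that touches the fluorine on this arm, and it went the wrong way. an at least 2.1-fold higher number from compound 1 to compound 3 (0.32 log units; beyond the scatter) also leaves compound 3 at the limit. Going by the values given here, no measured step moves the fluorine from one aromatic carbon to another, so nothing here says how much of the loss in compound 3 depends on where the fluorine sits.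

Compound 4 is therefore expected to remain close to compound 3, with the step of an at least 1.1-fold lower number from compound 3 to compound 4 (0.04 log units; that floor lies within the scatter) judged small and uncertain in direction. The estimate for compound 4 in this assay is 900 nM, within 250 nM to 3000 nM.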

Compound 4, half-maximal inhibitory concentration: 235 nM
Compound 4: the middle estimate sits 3.8-fold (0.58 log units) above what was measured; the whole stated range lies above it.
By their numbers in this assay, from the lowest: compound 2; then compounds 4 and 1 (each within the scatter of the next). At a limit, above all of these: compound 3.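

In this assay, the place of the fluorine on the benzyl arm turns out to count, not only its presence: with the same atoms joined differently, the change from 4-fluorophenyl to 3-fluorophenyl gives an at least 4.2-fold lower number from compound 3 to compound 4 (0.62 log units; beyond the scatter), so the loss in compound 3 does not follow from having a fluorine on this ring. The fluorine is still not free at the new place, with a 2.0-fold higher number from compound 2 to compound 4 (0.31 log units; beyond the scatter), while a 2.0-fold lower number from compound 1 to compound 4 (0.30 log units; within the scatter) leaves 3-fluorophenyl and pyridin-4-yl not told apart on this arm. Compound 3 remains a limit of the assay, so the effect of moving the fluorine is known only as a floor: the limit of > 1000 nM in this assay, at which 1 of the 4 values shown sits.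

On these data alone, whether the difference between the two fluorophenyl arms belongs to fluorine alone stays open, since a chlorine or a methoxy group at the same places on the benzyl arm would be needed to separate the atom from its place. Also open, as far as these compounds go, is whether the same ranking holds with a longer chain between the sulfonamide nitrogen and the ring, or with a different arm on the sulfonyl side.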